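The source may hold more compounds than are shown below. What is called first, only, known or untested is meant among the compounds shown, and "the series" means these compounds.

Measured so far:
Compound 1, `CC1CCN(c2cc(C(F)(F)F)ccc2CNC(=O)C(C)c2ccc(NS(C)(=O)=O)c(F)c2)CC1`: 0.9 nM
Compound 2, `CCCCCCSc1cc(C(F)(F)F)ccc1CNC(=O)C(C)c1ccc(NS(C)(=O)=O)c(F)c1`: 1.8 nM

In an assay on CHO cells for antagonist activity at transient receptor potential cation channel subfamily V member 1 (Homo sapiens), read by FLIPR (on this read-out higher numbers stand for weaker inhibition and lower numbers for stronger inhibition), compound 2 and compound 1 sit within the scatter of each other, so the two numbers cannot be told apart. Compound 3, `CC(C(=O)NCc1ccc(C(F)(F)F)cc1SC1CCCCC1)c1ccc(NS(C)(=O)=O)c(F)c1`, is not yet measured; it differs from compound 2 in one place: cyclohexyl in place of hexyl on a sulfur. Among the compounds with values here, the only measured step, a 2.0-fold higher number from compound 1 to compound 2 (0.30 log units; within the scatter), swapped the whole group on the aromatic carbon and still stayed within the scatter, so it bears only loosely on a chain-to-ring swap that keeps the sulfur. The step that is therefore expected is no change at the digits printed from compound 2 to compound 3 (within the scatter), nothing beyond the scatter. Compound 3 is estimated at 1.8 nM, between 0.6 nM and 5.5 nM.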

Compound 3, inhibition constant: 0.5 nM
For compound 3 the middle estimate is 3.6-fold (0.56 log units) above the measured one; measured number outside the range, below it.
By their numbers in this assay, from the lowest: compounds 3, 1 and 2 (each within the scatter of the next, the first and the last beyond it).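

In this assay, within the data shown here, the change from hexyl to cyclohexyl on the sulfur gives a 3.6-fold lower number from compound 2 to compound 3 (0.56 log units; beyond the scatter), the first step beyond the scatter at this position, although the count of six carbons stays the same. Replacing 4-methylpiperidin-1-yl with cyclohexylsulfanyl gives a 1.8-fold lower number from compound 1 to compound 3 (0.26 log units; within the scatter), so these two groups cannot be told apart. Nothing available explains why the ring and the chain differ. Still open, from the compounds shown here alone, is whether a cyclopentyl ring on the sulfur, or an oxygen in place of the sulfur, would give a similar number.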